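The source may hold more compounds than are shown below. What is called first, only, known or untested is meant among the compounds shown, and "the series" means these compounds.

Among the measured compounds shown here, compound 1 `O=C(Nc1cccc(-n2cc(-c3ccncc3)c(-c3cc(O)cc(Cl)c3)n2)c1)Nc1ccc(Cl)c(C(F)(F)F)c1` is one of two compounds measured in a functional assay on OVCAR-4 cells (Homo sapiens) for inhibition, read by sulforhodamine B assay, with a stated time of 48 h, tested at 0.1 uM; a higher number here means a weaker effect of the compound at the concentration tested, a lower number a stronger effect; in that test compound 1 gives 105%, the highest of the two numbers. Compound 2 `O=C(Nc1cccc(-n2cc(-c3ccncc3)c(-c3cc(O)cc(Cl)c3)n2)c1)Nc1ccc(Cl)c(Cl)c1` gives 95%, and the step of a number 10 percentage points lower from compound 1 to compound 2 (within the scatter) goes with chloro in place of trifluoromethyl on an aromatic carbon. Compound 3 `COc1cc(Cl)cc(-c2nn(-c3cccc(NC(=O)Nc4ccc(Cl)c(C(F)(F)F)c4)c3)cc2-c2ccncc2)c1` is not yet measured. It differs from compound 1 by methyl in place of hydrogen on an oxygen on an aromatic ring. For the measured compounds named here, no measured step touches this oxygen; the only known step, a number 10 percentage points lower from compound 1 to compound 2 (within the scatter), sits elsewhere and lies within the scatter. Compound 3 is therefore expected to show a number 5 percentage points lower from compound 1 to compound 3 (within the scatter), nothing beyond the scatter. The estimate for compound 3 is 100%, between 82% and 115%.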

Compound 3, a percentage reported as activity, at one concentration (the size of the read-out at that concentration, not a potency): 97%
The estimate for compound 3 lay 3 percentage points above the measured number; the range from low to high includes it.
By their numbers in this assay, from the lowest: compounds 2, 3 and 1 (each within the scatter of the next).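

Among the compounds shown here, replacing hydroxy with methoxy gives, in this assay, a number 8 percentage points lower from compound 1 to compound 3 (within the scatter), the first reading of any change at this oxygen. Putting methyl on the oxygen, which removes its hydrogen, therefore produces no difference that can be told from the scatter at this single concentration. Nothing measured here offers a reason for this result. On these data alone, whether an amine in place of the hydroxy, or a longer chain such as ethoxy on the oxygen, would move the number remains open. So does whether the methoxy and hydroxy compounds would differ at other concentrations.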